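A few compounds are considered here, and "the series" means these few. Any claim that something is new, unique, unknown or untested is made for them only; others in the source may bear on it.

Values in a functional assay on HOS cells (Homo sapiens) for antiproliferative activity, with a stated time of 72 h; on this read-out lower numbers stand for stronger inhibition and higher numbers for weaker inhibition:
- compound 1 `OC[C@H]1O[C@@H](n2cnc3c(NCc4ccc(F)cc4)ncnc32)[C@H](O)[C@@H]1O`: 13200 nM
- compound 2 `OC[C@H]1O[C@@H](n2cnc3c(NCc4ccccc4Br)ncnc32)[C@H](O)[C@@H]1O`: > 166000 nM (a limit)
- compound 3 `OC[C@H]1O[C@@H](n2cnc3c(NCc4ccc(Br)cc4)ncnc32)[C@H](O)[C@@H]1O`: > 166000 nM (a limit)

Compound 3 gives only a limit, > 166000 nM, and no number. This is the limit of > 166000 nM in this assay, at which 2 of the 3 values shown sit.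

The step to compound 4 `COc1cccc(CNc2ncnc3c2ncn3[C@@H]2O[C@H](CO)[C@@H](O)[C@H]2O)c1` puts 3-methoxyphenyl in place of 4-bromophenyl on a saturated chain carbon bound to a nitrogen on an aromatic ring.

Going by the values given here, no measured compound carries the entering group, so the evidence is indirect. Two measured steps change the same place: an at least 12-fold higher number from compound 1 to compound 3 (1.09 log units; beyond the scatter) and an at least 12-fold higher number from compound 1 to compound 2 (1.09 log units; beyond the scatter). Both are large and beyond the scatter, and both are bounded by a limit. The third, a step that the two limits leave unreadable from compound 2 to compound 3, says nothing about size.

Among the compounds with values here, compound 1 holds the only number, 13200 nM. Replacing the bromo-bearing group may therefore recover measurable activity, so a moderate step towards a lower number is expected, though a second limit reading remains quite possible. The expected change is an at least 2.7-fold lower number from compound 3 to compound 4 (0.44 log units; beyond the scatter). For compound 4 the estimated value is 60000 nM, with an expected range of 15000 nM to 166000 nM.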

Compound 4, half-maximal inhibitory concentration: > 166000 nM
Compound 4: a limit, no number (the forecaster's own chance of this, stated with the estimate: 40%); middle value at least 2.7-fold (0.44 log units) from the limit.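

Compound 4 gives only a limit, > 166000 nM, in this assay, so this reading is a limit and not a number. The earlier limits both came with a bromophenyl, whereas 3-methoxyphenyl carries no bromine and still gives no number, so among the compounds shown the loss of a measurable value does not go with bromine alone; the 4-fluorophenyl of compound 1 remains the only group at this position with a number. Against that group the change reads as an at least 12-fold higher number from compound 1 to compound 4 (1.09 log units; beyond the scatter), while the steps from compound 2 and from compound 3 to compound 4 cannot be read, as both ends of each are limits, and the position now gives almost a single reading: the limit of > 166000 nM in this assay, at which 3 of the 4 values shown sit.

As far as these compounds go, how far compound 2, compound 3 and compound 4 lie from one another stays unknown, and one number cannot show whether the value of compound 1 depends on the fluoro group itself. Also open, from the compounds shown here alone, is whether an unsubstituted phenyl, a 4-chlorophenyl or a 4-methoxyphenyl on a saturated chain carbon bound to a nitrogen on an aromatic ring would give a number in this assay.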